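Fluoro to methoxy on the pendant phenyl of an oxazole series

The source may report more compounds than this note shows. Statements on the series, on what has been measured and on what is new or still open speak of the compounds shown alone.

In a functional assay on MDA-MB-468 cells (Homo sapiens) for cytotoxicity, with a stated time of 48 h (a lower number here means a stronger inhibitor, a higher number a weaker inhibitor), compound 1 `O=[N+]([O-])c1ccc(CN2CCC(n3cc(CC(OCc4cc(-c5cccc(F)c5)no4)c4ccc(Br)cc4)nn3)CC2)cc1` gives 3000 nM. Compound 2 `COc1cccc(-c2cc(COC(Cc3cn(C4CCN(Cc5ccc([N+](=O)[O-])cc5)CC4)nn3)c3ccc(Br)cc3)on2)c1` reaches only the limit of this assay, > 25000 nM, a limit rather than a number (the limit of > 25000 nM in this assay, at which 1 of the 3 values shown sits). The change between them is methoxy in place of fluoro on an aromatic carbon, and the step is an at least 8.3-fold higher number from compound 1 to compound 2 (0.92 log units; beyond the scatter). Compound 3 `O=[N+]([O-])c1ccc(CN2CCC(n3cc(CC(OCc4cc(-c5ccccc5F)no4)c4ccc(Br)cc4)nn3)CC2)cc1` gives 4000 nM in this assay; it differs from compound 1 by 2-fluorophenyl in place of 3-fluorophenyl on an aromatic carbon, and the step of a 1.3-fold higher number from compound 1 to compound 3 (0.12 log units; within the scatter) lies within the scatter. Between compound 2 and compound 3 the step is an at least 6.2-fold lower number from compound 2 to compound 3 (0.79 log units; beyond the scatter).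

Compound 4 `COc1ccccc1-c1cc(COC(Cc2cn(C3CCN(Cc4ccc([N+](=O)[O-])cc4)CC3)nn2)c2ccc(Br)cc2)on1` is not yet measured in this assay. Relative to compound 3 it carries methoxy in place of fluoro on an aromatic carbon. This is the same kind of change as that from compound 1 to compound 2, but the place differs: there the methoxy stands meta to a large group, here ortho to a large group. The expectation rests on the step from compound 1 to compound 2, an at least 8.3-fold higher number from compound 1 to compound 2 (0.92 log units; beyond the scatter), which was beyond the scatter. For compound 4 the expected step is a 6.3-fold higher number from compound 3 to compound 4 (0.80 log units; beyond the scatter). Compound 4 is therefore estimated at 25000 nM in this assay, between 8000 nM and 60000 nM, with a real chance that only a limit is returned.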

Compound 4, half-maximal inhibitory concentration: > 25000 nM
Compound 4: no number, only a limit; the forecaster's own chance of this, stated with the estimate: 55%; the middle value lies on the limit itself.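

In this assay compound 4 returns > 25000 nM, a limit and not a number. Methoxy in place of fluoro raises the number on this core as well, with an at least 6.2-fold higher number from compound 3 to compound 4 (0.79 log units; beyond the scatter), and the wider change from 3-fluorophenyl to 2-methoxyphenyl gives an at least 8.3-fold higher number from compound 1 to compound 4 (0.92 log units; beyond the scatter), while the step between the two compounds at the limit cannot be read. The direction of the change therefore carries from one core to the other in these two pairs, but nothing shows that its size carries with it, and two pairs make no rule for the series: the same change on two cores in this assay, an at least 8.3-fold higher number (0.92 log units; beyond the scatter) from compound 1 to compound 2 and an at least 6.2-fold higher number (0.79 log units; beyond the scatter) from compound 3 to compound 4; the limit leaves it open whether they differ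

As far as these compounds go, how far the two methoxy compounds lie past the limit remains open, so the two positions of the methoxy cannot be ranked. Also open, from the compounds shown here alone, is whether the loss is particular to methoxy or would recur with a hydroxy, ethoxy or chloro group in the place of the fluoro on the pendant phenyl.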